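The source may report more compounds than this note shows. Statements on the series, on what has been measured and on what is new or still open speak of the compounds shown alone.

Measured compounds in an assay on isolated protein for inhibition of 3',5'-cyclic-AMP phosphodiesterase 4A (Cavia porcellus), read by cAMP accumulation, tested at 50 uM; a higher number here means a stronger effect of the compound at the concentration tested, a lower number a weaker effect:
Compound 1, `O=C1CC(c2ccccc2)Cc2[nH]c(=O)c(C(=O)c3ccccc3)cc21` — 1.7%
Compound 2, `O=C1CCCc2[nH]c(=O)c(S(=O)(=O)c3ccccc3)cc21` — 4.7%

Only these two compounds have been measured, and neither of them shows much effect. Compound 2 gives 4.7% in this assay, and compound 1 gives 1.7%; the two numbers lie within the scatter of each other, so the data do not separate compound 2 from compound 1. Going by the values given here, no step between two compounds that differ in one place has been measured. The compound to be measured next is compound 3, `O=C1CC(c2ccccc2)Cc2[nH]c(=O)c(S(=O)(=O)c3ccccc3)cc21`. It differs from compound 2 by phenyl in place of hydrogen on a saturated ring carbon. Because compound 2 gives 4.7% and compound 1, which already carries a phenyl on a saturated ring carbon, gives 1.7%, compound 3 is expected to stay in the same low region. The step of a number 0.7 percentage points lower from compound 2 to compound 3 (within the scatter) is estimated to be none beyond the scatter. Compound 3 is expected to give 4%, within a range from -4% to 14%.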

Compound 3, a percentage reported as inhibition, at one concentration (the size of the read-out at that concentration, not a potency): 5.7%
Estimate against measurement, compound 3: 1.7 percentage points below; the measured number falls inside the stated range.
By their numbers in this assay, from the lowest: compounds 1, 2 and 3 (each within the scatter of the next).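

Phenyl in place of hydrogen on a saturated ring carbon gives, in this assay, a number 1 percentage points higher from compound 2 to compound 3 (within the scatter), so with the phenylsulfonyl group present this position accepts the added ring without a change that the data can separate from the scatter. Phenylsulfonyl in place of benzoyl on an aromatic carbon, with that phenyl present, gives a number 4 percentage points higher from compound 1 to compound 3 (within the scatter), so this exchange cannot be told from the scatter either. Nothing measured alongside these numbers bears on why the readings stay so low.

The compounds shown leave open whether an amine or a carboxylic acid in place of phenyl on the saturated ring carbon would move the reading beyond the scatter. Going by these compounds, it is equally open whether a longer chain in place of phenylsulfonyl on the aromatic carbon would do so.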